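The compounds below may be only part of what the source reports. "The series", "measured", "known", "first", "only" and "open" are said of these compounds alone.

Compound 1 `O=C(NC1CC1)c1cccc(S(=O)(=O)Oc2ccc(-c3cncn3C3CCN(C(=O)c4ccc([N+](=O)[O-])cc4)CC3)cc2)c1` was tested in an assay on HEK293 cells for antagonist activity at P2X purinoceptor 7 (Homo sapiens), read by fluorescence, with a stated time of 2 h (a lower number here means a stronger inhibitor, a higher number a weaker inhibitor), where compound 1 gives 152 nM. Compound 2 `CN(C)c1ccc(C(=O)N2CCC(n3cncc3-c3ccc(OS(=O)(=O)c4cccc(C(=O)NC5CC5)c4)cc3)CC2)cc1` differs from compound 1 in one spot only dimethylamino in place of nitro on an aromatic carbon and in this assay compound 2 gives 0.49 nM. The result of that single change was a 310-fold lower number from compound 1 to compound 2 (2.49 log units; beyond the scatter). Compound 3 `O=C(c1ccc([N+](=O)[O-])cc1)N1CCN(c2cc(=O)[nH]c(=O)n2Cc2ccc(OS(=O)(=O)c3cccc4cnccc34)cc2)CC1` is built on a different core, and the difference between the two cores is not broken down here. In this assay compound 3 gives 27 nM. Compound 4 `CN(C)c1ccc(C(=O)N2CCN(c3cc(=O)[nH]c(=O)n3Cc3ccc(OS(=O)(=O)c4cccc5cnccc45)cc3)CC2)cc1` carries the same change made on the core of compound 3 (dimethylamino in place of nitro on an aromatic carbon); the surroundings of the changed spot are described in the same words for both pairs, so this counts as the same change rather than merely one of the same kind. For the measured compounds named here, the expectation for compound 4 rests on a 310-fold lower number from compound 1 to compound 2 (2.49 log units; beyond the scatter), which is the only earlier example of this change and was seen on a different core. A large step is expected, estimated somewhat smaller than that earlier one, namely a 90-fold lower number from compound 3 to compound 4 (1.95 log units; beyond the scatter). Compound 4 is therefore estimated at 0.3 nM, with a likely range from 0.05 nM to 3 nM.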

Compound 4, half-maximal inhibitory concentration: 1.53 nM
The estimate for compound 4 lay 5.1-fold (0.71 log units) below the measured number, within the range that was stated.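

In this assay, dimethylamino in place of nitro again gives a lower number on the second core, with an 18-fold lower number from compound 3 to compound 4 (1.25 log units; beyond the scatter) beyond the scatter, so the direction of the step carried over from the core of compound 1 to the core of compound 3. The size of the step did not carry over, as the two steps stand clearly apart: the same change on two cores in this assay, a 310-fold lower number (2.49 log units; beyond the scatter) from compound 1 to compound 2 and an 18-fold lower number (1.25 log units; beyond the scatter) from compound 3 to compound 4, 18-fold (1.24 log units) apart, beyond the scatter of two such steps. For the compounds shown here, with only two pairs, this shows that the direction held on these two cores while the size differed, but it does not show which feature of the cores goes with the larger step, or how large the step would be on a third core.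

The compounds shown carry only nitro or dimethylamino at this spot, so it stays open how a plain amino group, a methoxy group or a chlorine atom would read on either core. As far as these compounds go, it also stays open whether a longer chain on the nitrogen, such as diethylamino, would keep the low numbers seen with dimethylamino.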